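The source may hold more compounds than are shown below. What is called first, only, known or untested is meant among the compounds shown, and "the series" means these compounds.

Three compounds have been measured so far in a functional assay on A549 cells (Homo sapiens) for antiproliferative activity, read by sulforhodamine B assay, with a stated time of 48 h (a higher number here means a weaker inhibitor of growth, a lower number a stronger inhibitor of growth), and give these values:

- Compound 1 `S=c1[nH]nc(C2=C(Cl)c3ccccc3CCC2)o1` gives 4960 nM
- Compound 2 `Cc1ccc(-c2nnc(C3=C(Cl)c4ccccc4CCC3)o2)cc1` gives 3420 nM
- Compound 3 `Cc1cc2c(cc1C)C(Cl)=C(c1nnc(-c3ccccc3)o1)CCC2` gives 1960 nM

Compound 3 (1960 nM) has a lower number than compound 1 (4960 nM), and that gap lies beyond the scatter. Its value and that of compound 2 (3420 nM) lie within the scatter of each other.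

The next compound to be tested is compound 4 `Cc1cc2c(cc1C)C(Cl)=C(c1nnc(-c3ccc(F)cc3)o1)CCC2` and it differs from compound 3 in one place. The difference is fluoro in place of hydrogen on an aromatic carbon and amounts to fluoro in place of hydrogen on an aromatic carbon, so that phenyl becomes 4-fluorophenyl.

For the measured compounds named here, no measured pair here differs in one place, so the data give no direct guide to this change. In this assay a step within the scatter is expected, with no firm direction. The estimated step is a 1.1-fold lower number from compound 3 to compound 4 (0.04 log units; within the scatter) in this series. For compound 4 the expected value is 1800 nM with an estimated range from 800 nM to 3800 nM in this assay.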

Compound 4, concentration for 50% growth inhibition: 2810 nM
Compound 4: middle estimate off by 1.6-fold (0.19 log units), on the low side, within the range that was stated.
By their numbers in this assay, from the lowest: compounds 3, 4, 2 and 1 (each within the scatter of the next, the first and the last beyond it).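

In this assay, fluoro in place of hydrogen on an aromatic carbon, para to a large group, gives a 1.4-fold higher number from compound 3 to compound 4 (0.16 log units; within the scatter) and so does not separate 4-fluorophenyl from phenyl at this position. For the compounds shown here, this is the first pair that differs in one place, and it shows that this position accepts a fluoro group with no step beyond the scatter. Nothing measured here bears on why the step has this size.

Going by these compounds, whether another group at this position, such as methoxy, an amine or a carboxylic acid, would give a step beyond the scatter remains open. Also open, on these data alone, is whether fluoro elsewhere on this six-membered aromatic ring, or chloro in its place, would behave as fluoro does here.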